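This account rests on a few compounds, and the source may have more. Where it says the series, first, only, none or still open, it means among the compounds named here.

In a functional assay on the whole organism with Mus musculus as the target (on this read-out higher numbers stand for an effect only at larger amounts of compound and lower numbers for an effect already at smaller amounts), compound 1 `Cc1c(N)cc2c(c1C)OC(C)(C)C2` gives 24.4 mg/kg. Compound 2 `Cc1c(C)c2c(c([N+](=O)[O-])c1N)CC(C)(C)O2` gives only a limit, > 100 mg/kg. From the compounds shown here alone, compound 3 `Cc1c(C)c2c(c(N)c1N)CC(C)(C)O2` also gives only a limit, > 50 mg/kg, so its true place on the scale remains open. Compound 4 `Cc1c(C)c2c(c(N(C)C)c1N)CC(C)(C)O2` carries dimethylamino in place of amino on an aromatic carbon, ortho to a fused ring: dimethylamino in place of amino on an aromatic carbon. Two measured steps at that carbon bear on this, an at least 4.0-fold higher number from compound 1 to compound 2 (0.61 log units; beyond the scatter) and an at least 2.0-fold higher number from compound 1 to compound 3 (0.31 log units; beyond the scatter), and both moved to higher numbers. The third, a step that the two limits leave unreadable from compound 2 to compound 3, adds nothing. Compound 4 is therefore expected to stay with the high-number compounds, with no shift beyond the scatter. The expected change is a step that the limit leaves unreadable from compound 3 to compound 4. For compound 4 the estimated value is 70 mg/kg, with an expected range of 30 mg/kg to 200 mg/kg.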

Compound 4, dose for 50% inhibition: 22.3 mg/kg
Beside the measured number, compound 4's estimate is 3.1-fold (0.50 log units) above it, and the stated range ends above it.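

In this assay, dimethylamino at this aromatic carbon behaves differently from the other substituents carrying nitrogen: in place of amino it gives an at least 2.2-fold lower number from compound 3 to compound 4 (0.35 log units; beyond the scatter), and in place of nitro it gives an at least 4.4-fold lower number from compound 2 to compound 4 (0.65 log units; beyond the scatter). Against hydrogen it gives a 1.1-fold lower number from compound 1 to compound 4 (0.04 log units; within the scatter), so dimethylamino is the first group here that does not move the number up from compound 1. The position therefore tolerates a substituent, and the outcome depends on which group enters.

From the compounds shown here alone, the first two steps rest on limits, so their true size stays open. Going by these compounds, whether methylamino or a cyclic amine such as pyrrolidine would read like dimethylamino at this carbon also remains open.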